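Vero cytotoxicity: carbonyl substituent series, compound 4

A few compounds are considered here, and "the series" means these few. Any claim that something is new, unique, unknown or untested is made for them only; others in the source may bear on it.

Measured so far in an ADME assay on Vero cells (Chlorocebus sabaeus) for cytotoxicity, read by resazurin assay, with a stated time of 3 days; on this read-out lower numbers stand for stronger inhibition and higher numbers for weaker inhibition:
- compound 1, `CCN(CC)c1cc2[nH]c(C3CCCCC3)nc2cc1NC(=O)NCc1ccccc1`: > 100 ug/mL, a limit of the assay
- compound 2, `CCN(CC)c1cc2[nH]c(C3CCCCC3)nc2cc1NC(=O)c1ccc(OC(F)F)cc1`: > 100 ug/mL, a limit of the assay
- compound 3, `C=Cc1cccc(C(=O)Nc2cc3nc(C4CCCCC4)[nH]c3cc2N(CC)CC)c1`: > 100 ug/mL, a limit of the assay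

Compound 3 therefore stands at the assay limit, and the same holds for the other two values shown; the common footing is the limit of > 100 ug/mL in this assay, at which 3 of the 3 values shown sit. The steps that vary the group on the carbonyl carbon are a step that the two limits leave unreadable from compound 1 to compound 2, a step that the two limits leave unreadable from compound 1 to compound 3 and a step that the two limits leave unreadable from compound 2 to compound 3. None of them is readable in size, so the numbers give no measure of how much this position moves cytotoxicity, only that each variant so far reaches the limit.

Compound 4, `CCc1ccc(C(=O)Nc2cc3nc(C4CCCCC4)[nH]c3cc2N(CC)CC)cc1`, is not yet measured. It differs from compound 3 by 4-ethylphenyl in place of 3-vinylphenyl on a carbonyl carbon. The bearing steps are the three above, all at the limit, and they offer no readable direction or size. The step of a number no higher from compound 3 to compound 4 (the limit leaves the size open) in this assay is therefore expected to be none beyond the scatter, with the result most likely reported again as a limit. For compound 4 the estimate in this assay is 100 ug/mL. The expected range for compound 4 runs from 60 ug/mL to 200 ug/mL.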

Compound 4, half-maximal inhibitory concentration: > 100 ug/mL
Compound 4 gave a limit, no number; the forecaster's own chance of this, stated with the estimate: 80%; the middle value lies on the limit itself.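

In this assay compound 4 gives > 100 ug/mL as a limit of the assay, not a number. Among these compounds, no step among compound 1, compound 2, compound 3 and compound 4 can be read, because all values share one footing: the limit of > 100 ug/mL in this assay, at which 4 of the 4 values shown sit. The compounds shown leave open whether any group on the carbonyl carbon changes cytotoxicity, and by how much.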